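The source may hold more compounds than are shown below. What is called first, only, known or untested is meant among the compounds shown, and "the series" means these compounds.

Of the compounds shown here, three have so far been measured in a functional assay on the whole organism for inhibition, with Cicer arietinum as the target, with a stated time of 7 days; a higher number here means a weaker inhibitor, a lower number a stronger inhibitor. Compound 1 `CN(C)C(=S)SCc1nc2ccccc2[nH]1` gives 2120 nM in this assay. Compound 2 `O=C(CC(SC(=S)N1CCCC1)c1ccccc1)c1ccccc1` gives 1670 nM, and compound 3 `O=C(CC(SC(=S)N1CCCCC1)c1ccccc1)c1ccccc1` gives 1850 nM. Going by the values given here, the number for compound 3 lies within the scatter of both other numbers, so no order among the three can be read from them; the one measured step between neighbouring structures, a 1.1-fold higher number from compound 2 to compound 3 (0.04 log units; within the scatter), is itself within the scatter.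

Compound 4 `O=C(CC(SC(=S)N1CCOCC1)c1ccccc1)c1ccccc1` has not yet been measured. It differs from compound 3 in one place: morpholin-4-yl in place of piperidin-1-yl on a thiocarbonyl carbon. Among the compounds with values here, no measured pair exchanges a morpholin-4-yl for a piperidin-1-yl, so the only step that bears on this change is the earlier exchange of the ring on the thiocarbonyl carbon, a 1.1-fold higher number from compound 2 to compound 3 (0.04 log units; within the scatter), which stayed within the scatter. On that basis a step of a similar size, with no direction beyond the scatter, is expected, namely a 1.1-fold higher number from compound 3 to compound 4 (0.03 log units; within the scatter). For compound 4 the value in this assay is accordingly estimated at 2000 nM, with a range from 1000 nM to 4200 nM.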

Compound 4, half-maximal inhibitory concentration: 1650 nM
Beside the measured number, compound 4's estimate is 1.2-fold (0.08 log units) above it; measured number inside the range.
By their numbers in this assay, from the lowest: compounds 4, 2, 3 and 1 (each within the scatter of the next).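

In this assay, morpholin-4-yl in place of piperidin-1-yl on a thiocarbonyl carbon gives a 1.1-fold lower number from compound 3 to compound 4 (0.05 log units; within the scatter), and morpholin-4-yl in place of pyrrolidin-1-yl at the same place gives a 1.0-fold lower number from compound 2 to compound 4 (0.01 log units; within the scatter), so both exchanges stay within the scatter. Going by these compounds alone, the earlier compounds compared only two rings without a second hetero atom at this place, whereas morpholin-4-yl brings a ring oxygen, counted as a hydrogen-bond acceptor, and the numbers for compound 2, compound 3 and compound 4 still cannot be told apart. This position has thus taken three different six- or five-membered non-aromatic rings with no readable change in this whole-organism read-out, and no supporting measurement is available to explain that result.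

The compounds shown leave open whether a group of another kind on the thiocarbonyl carbon, such as an open diethylamino chain or a piperazin-1-yl ring carrying a free amine, would move the number beyond the scatter. They also leave open whether a chlorine or a methoxy group on either phenyl ring of the shared core would do so.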